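From 2-fluorobenzyl to 3-aminobenzyl: what compound 4 may show

The compounds below may be only part of what the source reports. "The series", "measured", "known", "first", "only" and "open" are said of these compounds alone.

Values in a toxicity assay on NIH3T3 cells (Mus musculus) for cytotoxicity, read by resazurin assay; a higher number here means that more compound is needed for the effect, a lower number that less compound is needed:
- compound 1 (`COC(=O)c1ccc(NCc2cncn2Cc2ccc(N)cc2)cc1-c1ccccc1`) gives > 10000 nM as a limit of the assay, not a number
- compound 2 (`COC(=O)c1ccc(NCc2cncn2Cc2ccccc2Br)cc1-c1ccccc1`) gives 10000 nM
- compound 3 (`COC(=O)c1ccc(NCc2cncn2Cc2ccccc2F)cc1-c1ccccc1`) has "not determined" (no result reported) as its entry

Going by the values given here, compound 3 holds no number of its own, so no step in this assay can be sized from it. Compound 4 (`COC(=O)c1ccc(NCc2cncn2Cc2cccc(N)c2)cc1-c1ccccc1`) carries 3-aminophenyl in place of 2-fluorophenyl on a saturated chain carbon bound to an aromatic nitrogen. Among the compounds with values here, the only measured step at that place shows a number no higher from compound 1 to compound 2 (the limit leaves the size open), with 2-bromophenyl in place of 4-aminophenyl. It gives no size to carry over. Within the data shown here, compound 2 supplies the only number (10000 nM), so compound 4 is expected to lie near it, with no shift beyond the scatter. Compound 4 may return only a limit. Compound 4 is estimated at 10000 nM (expected range 4000 nM to 25000 nM).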

Compound 4, half-maximal effective concentration: > 10000 nM
Compound 4: no number, only a limit (the forecaster's own chance of this, stated with the estimate: 60%); the middle value lies on the limit itself.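

Compound 4, like compound 1, ends at a limit of this assay and not at a number, so at this place on a saturated chain carbon bound to an aromatic nitrogen, 3-aminophenyl gives the same kind of result as 4-aminophenyl. The exchange of 2-bromophenyl for 3-aminophenyl reads as a number no lower from compound 2 to compound 4 (the limit leaves the size open), while neither the size of that step nor the step between the two aminophenyl compounds can be read. Any finer ranking at this place is out of reach because of where the values sit: the limit of > 10000 nM in this assay, at which 2 of the 4 values shown sit.

The compounds shown leave open whether any group at this place gives a value clearly lower than that of compound 2, and compound 3 offers no value to help. A carboxylic acid or a longer chain at this place remains untested among the compounds shown here.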